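This account rests on a few compounds, and the source may have more. Where it says the series, first, only, none or still open, it means among the compounds named here.

Measured so far in a physicochemical assay for solubility, measured as kinetic solubility; on this read-out lower numbers stand for lower solubility and higher numbers for higher solubility:
- compound 1 `CCC/N=C1\S/C(=C\c2ccc(O)c(Cl)c2)C(=O)N1c1ccccc1C` gives 79000 nM
- compound 2 `Cc1ccccc1N1C(=O)/C(=C/c2ccc(O)c(Cl)c2)S/C1=N\CCCF` gives 20000 nM
- compound 3 `CCC/N=C1\S/C(=C\c2ccc(O)c(C)c2)C(=O)N1c1ccccc1C` gives 78000 nM

Compound 1 has the highest of the three numbers, but its gap to compound 3, a 1.0-fold lower number from compound 1 to compound 3 (0.01 log units; within the scatter), is within the scatter, so these two cannot be told apart; only compound 2 sits clearly lower, by a 4.0-fold lower number from compound 1 to compound 2 (0.60 log units; beyond the scatter).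

Compound 4 `CCC/N=C1\S/C(=C\c2ccc(O)c(Cl)c2)C(=O)N1c1ccccc1OC` differs from compound 1 by methoxy in place of methyl on an aromatic carbon. Neither measured step tests this exact change. The step from compound 1 to compound 3 also exchanges one aromatic substituent for another, on the other ring, and produced no movement beyond the scatter. The step from compound 1 to compound 2 alters the chain instead, so it says little here. On this basis the change to compound 4 is expected to give a step of a 1.1-fold higher number from compound 1 to compound 4 (0.06 log units; within the scatter) in this assay, small and most likely within the scatter, leaning slightly upward if anywhere. Compound 4 is therefore estimated at 90000 nM, with a range from 45000 nM to 180000 nM.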

Compound 4, solubility: 79000 nM
Estimate against measurement, compound 4: 1.1-fold (0.06 log units) above; measured number inside the range.
By their numbers in this assay, from the lowest: compound 2; then compounds 3, 1 and 4 (each within the scatter of the next).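

In this assay, for the compounds shown here, the exchange of 2-methylphenyl for 2-methoxyphenyl gives no change at the digits printed from compound 1 to compound 4 (within the scatter), the first reading at this ring position, since the earlier steps changed only the chain and the other aromatic ring. At least in this one pair, a group with one more heavy atom, an oxygen that counts as a hydrogen-bond acceptor, fits on this aromatic carbon, ortho to a large group, with no shift beyond the scatter.

As far as these compounds go, it remains open whether an ethoxy group, an amine or a carboxylic acid at this place would also leave the number unmoved. Also open, from the compounds shown here alone, is whether the same exchange would read the same on compound 2, which carries the fluoro chain and sits clearly lower. No measured information available here accounts for the result of this exchange.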